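The source may report more compounds than this note shows. Statements on the series, on what has been measured and on what is new or still open speak of the compounds shown alone.

Working notes on the series. In a physicochemical assay for lipophilicity (on this read-out higher numbers stand for higher lipophilicity and lower numbers for lower lipophilicity), compound 1 `CS(=O)(=O)Cc1cc(C2=CCOCC2)nc(-c2cccc(O)c2)n1` gives 3.3 and compound 2 `Oc1cccc(-c2nccc(C3CCOCC3)n2)c1` gives 3.3, so these two values agree. Compound 3 `CC(C)(c1cc([C@@]23CCOC[C@@H]2C3)nc(-c2ccc(NC(=S)NCCO)cc2)n1)S(C)(=O)=O` gives 3.9, the highest of the three and beyond the scatter of both others. Compound 4 `CCNC(=O)Nc1ccc(-c2nc(C(C)(C)S(C)(=O)=O)cc([C@@]34CCOC[C@@H]3C4)n2)cc1` differs from compound 3 in one place: a group of 5 heavy atoms (3 carbon, 1 nitrogen, 1 oxygen; no ring) in place of a group of 6 heavy atoms (3 carbon, 1 nitrogen, 1 oxygen, 1 sulfur; no ring), on a nitrogen on an aromatic ring. The entering group is ethylcarbamoyl. Within the data shown here, no measured pair differs in one place, so no step sizes this change directly, and the expectation rests on compound 3 at 3.9. A small upward move in this assay, not beyond the scatter, is expected, with the estimated step of a number 0.20 log units higher from compound 3 to compound 4 (within the scatter). For compound 4 the estimate is 4.1, with an expected range of 3.6 to 4.6.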

Compound 4, partition coefficient: 4.7
Compound 4: the middle estimate sits 0.60 log units below what was measured; measured number outside the range, above it.
By their numbers in this assay, from the lowest: compounds 1 and 2 (each within the scatter of the next); then compound 3; then compound 4.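

Among these compounds, at this position, on a nitrogen on an aromatic ring, this assay gives the first one-place step, a number 0.80 log units higher from compound 3 to compound 4 (beyond the scatter), with ethylcarbamoyl entering. The read-out therefore responds to this change, and it rises even though the entering group has fewer heavy atoms and no sulfur. Nothing at hand accounts for the size of the step.

From the compounds shown here alone, whether the rise follows ethylcarbamoyl specifically or any replacement of the leaving group stays open. A longer chain in place of the ethyl, or an acetyl group on the same nitrogen, would help separate the two.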